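Carbonyl-side replacements in the shared core series

The source may hold more compounds than are shown below. What is called first, only, known or untested is meant among the compounds shown, and "the series" means these compounds.

Measured so far:
compound 1 `O=C(NCc1cccc(Cn2cnc3ccccc32)c1)c1cc(Br)c[nH]1`: 16 nM
compound 2 `O=C(NCc1cccc(Cn2cnc3ccccc32)c1)c1ccc(Br)cc1`: 134 nM

In an assay for inhibition of Indoleamine 2,3-dioxygenase 1 (Homo sapiens), read by HPLC, with a stated time of 48 h (on this read-out higher numbers stand for weaker inhibition and lower numbers for stronger inhibition), compound 1 gives 16 nM, the lowest of the two numbers in hand. Compound 2 gives 134 nM. Among the compounds with values here, the single measured step, an 8.4-fold higher number from compound 1 to compound 2 (0.92 log units; beyond the scatter), is the only comparison available at the carbonyl carbon.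

Compound 3 `N#Cc1ccc(C(=O)NCc2cccc(Cn3cnc4ccccc43)c2)cc1` differs from compound 1 by 4-cyanophenyl in place of 4-bromo-1H-pyrrol-2-yl on a carbonyl carbon. Within the data shown here, this change shares with the measured step the loss of the 4-bromo-1H-pyrrol-2-yl group and the entry of a six-membered aromatic ring of carbon only on the carbonyl carbon; only the substituent on that ring differs, and no measured pair speaks to the nitrile against bromine. The step to compound 2 is therefore taken as the guide, and a higher number is expected for compound 3, an 8.1-fold higher number from compound 1 to compound 3 (0.91 log units; beyond the scatter). Compound 3 is estimated at 130 nM, with a range of 40 nM to 400 nM.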

Compound 3, half-maximal inhibitory concentration: 90 nM
The estimate for compound 3 lay 1.4-fold (0.16 log units) above the measured number; the range from low to high includes it.
By their numbers in this assay, from the lowest: compound 1; then compounds 3 and 2 (each within the scatter of the next).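

In this assay a second replacement of the 4-bromo-1H-pyrrol-2-yl group on the carbonyl carbon also gives a step beyond the scatter (a 5.6-fold higher number from compound 1 to compound 3 (0.75 log units; beyond the scatter)), so the gap to compound 1 now rests on two six-membered aromatic rings of carbon only, not one. Within the data shown here, the change of cyano in place of bromo on an aromatic carbon, a comparison the earlier compounds could not give, stays within the scatter (a 1.5-fold lower number from compound 2 to compound 3 (0.17 log units; within the scatter)), and the two substituents cannot be told apart on this read-out. No measurement at hand explains the gap between the pyrrole and these rings.

Still open, from the compounds shown here alone, is whether the gap follows the ring or its substituent, which a 4-cyano-1H-pyrrol-2-yl group on the same carbonyl carbon would test. Also open, going by these compounds, is how far the substituent tolerance extends, for example to 4-aminophenyl or 4-carboxyphenyl.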